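Vinyl sulfone series: chloro for fluoro on the aryl sulfone

The compounds below may be only part of what the source reports. "The series", "measured", "known", "first", "only" and "open" are said of these compounds alone.

Measured compounds:
compound 1 `O=S(=O)(/C=C/c1ncccc1F)c1ccc(F)cc1`: 542 nM
compound 2 `O=S(=O)(/C=C/c1ncccc1Cl)c1ccc(F)cc1`: 231 nM

In an assay on U2OS cells for activation of nuclear factor erythroid 2-related factor 2 (Homo sapiens), read by beta-arrestin recruitment, with a stated time of 6 h (a lower number here means that less compound is needed, a higher number that more compound is needed for the effect), compound 1 gives the highest of the two numbers; the nearest is compound 2, reached by a 2.3-fold lower number from compound 1 to compound 2 (0.37 log units; beyond the scatter). Compound 3 `O=S(=O)(/C=C/c1ncccc1F)c1ccc(Cl)cc1` is not yet measured. It differs from compound 1 by chloro in place of fluoro on an aromatic carbon. Among the compounds with values here, the one measured step of the same kind, a 2.3-fold lower number from compound 1 to compound 2 (0.37 log units; beyond the scatter), changes the same pair of halogens but on the other ring, the one carrying the nitrogen; no step on the six-membered aromatic ring of carbon only has been measured. That step is modest and downward, so for compound 3 a downward step of similar or smaller size is expected in this assay, a 1.5-fold lower number from compound 1 to compound 3 (0.19 log units; within the scatter). The estimate for compound 3 is therefore 350 nM, with a range of 150 nM to 900 nM.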

Compound 3, half-maximal effective concentration: 286 nM
Beside the measured number, compound 3's estimate is 1.2-fold (0.09 log units) above it, within the range that was stated.
By their numbers in this assay, from the lowest: compounds 2, 3 and 1 (each within the scatter of the next, the first and the last beyond it).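

In this assay, within the data shown here, chloro in place of fluoro on an aromatic carbon of the six-membered aromatic ring of carbon only, para to a large group, gives a 1.9-fold lower number from compound 1 to compound 3 (0.28 log units; within the scatter) and so is the first reading of this position; the exchange is tolerated here, but no change can be claimed from this step alone. Among these compounds, the same exchange on the ring carrying the nitrogen gave a 2.3-fold lower number from compound 1 to compound 2 (0.37 log units; beyond the scatter) and is beyond the scatter, so only that step supports a real shift. Nothing available explains either step or shows whether the two positions truly respond differently.

From the compounds shown here alone, whether chloro at both places in one compound would combine the two steps remains open. The compounds shown also leave open how this position responds to a non-halogen group such as methoxy, nitrile or an amine.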